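The compounds below may be only part of what the source reports. "The series", "measured", "known", "first", "only" and "open" are said of these compounds alone.

Three chalcones have been measured in a functional assay on HCT-116 cells (Homo sapiens) for antiproliferative activity, read by sulforhodamine B assay, with a stated time of 3 days, tested at 50 uM; a higher number here means a stronger effect of the compound at the concentration tested, a lower number a weaker effect. Compound 3 `O=C(/C=C/c1ccc(F)cc1)c1ccccc1` gives 100%, and compound 1 `O=C(/C=C/c1ccc(Cl)cc1)c1ccccc1` gives 100%. The only difference between them is chloro in place of fluoro on an aromatic carbon, and that step, no change at the digits printed from compound 3 to compound 1 (within the scatter), made no measurable difference. Compound 2 `Cc1ccc(COc2ccc(C(=O)/C=C/c3ccc(F)cc3)cc2)cc1` carries a larger group on its other ring; the difference between its core and that of compound 3 is not broken down here. In this assay compound 2 gives 15.4%, the lowest of the three numbers and far below both compound 1 and compound 3.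

Compound 4 `Cc1ccc(COc2ccc(C(=O)/C=C/c3ccc(Cl)cc3)cc2)cc1` has not yet been measured. It differs from compound 2 by chloro in place of fluoro on an aromatic carbon, the same change that leads from compound 3 to compound 1, at the same place. Because the step from compound 3 to compound 1 was no change at the digits printed from compound 3 to compound 1 (within the scatter), the same change is expected to move compound 2 little, giving a step of about a number 4.6 percentage points higher from compound 2 to compound 4 (within the scatter). Compound 4 is therefore estimated at 20%, most likely between 5% and 45%.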

Compound 4, a percentage reported as inhibition, at one concentration (the size of the read-out at that concentration, not a potency): 16.9%
The estimate for compound 4 lay 3.1 percentage points above the measured number; the measured number falls inside the stated range.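

In this assay, placing chloro where fluoro stood on the larger core gives a number 1.5 percentage points higher from compound 2 to compound 4 (within the scatter). Set beside the same change on the smaller core, the step carries over from one core to the other without a visible difference: the same change on two cores in this assay, no change at the digits printed (within the scatter) from compound 3 to compound 1 and a number 1.5 percentage points higher (within the scatter) from compound 2 to compound 4, 1.5 percentage points apart, within the scatter of two such steps. This shows that in these two pairs the swap from 4-fluorophenyl to 4-chlorophenyl leaves the read-out where it was, whether the core reads high or low, but each reading comes from a single concentration and is not a potency, so any difference between the two halogens at other concentrations stays unseen, and two pairs make no general rule.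

The compounds shown leave open whether a group other than these two halogens at the same place, such as a methoxy group, an amine or a carboxylic acid, would be just as quiet. They also leave open whether the swap would stay this small on a third core.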